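Compound 1 to compound 4 against an assay limit

The source may report more compounds than this note shows. Statements on the series, on what has been measured and on what is new or still open speak of the compounds shown alone.

Compound 1 `CC(=O)Oc1cc(C(=O)C2=C(O)[C@]3(CC=C(C)C)C[C@@H](C/C=C(\C)CCC=C(C)C)[C@](C)(CCC=C(C)C)[C@](CC=C(C)C)(C2=O)C3=O)ccc1O`: > 20000 nM
Compound 2 `CC(=O)Oc1ccc(C(=O)C2=C(O)[C@]3(CC=C(C)C)C[C@@H](C/C=C(\C)CCC=C(C)C)[C@](C)(CCC=C(C)C)[C@](CC=C(C)C)(C2=O)C3=O)cc1OC(C)=O`: > 20000 nM
Compound 3 `CC(C)=CCC/C(C)=C/C[C@@H]1C[C@]2(CC=C(C)C)C(=O)[C@@](CC=C(C)C)(C(=O)C(C(=O)c3ccc(OCC(=O)O)c(OCC(=O)O)c3)=C2O)[C@@]1(C)CCC=C(C)C`: > 20000 nM

All measurements come from a functional assay on HCC827 cells (Homo sapiens) for inhibition, read by MTT assay, with a stated time of 72 h; on this read-out higher numbers stand for weaker inhibition and lower numbers for stronger inhibition. Compound 1 stands at > 20000 nM, which is a limit of the assay and not a number. It is not alone there, as the series shows (the limit of > 20000 nM in this assay, at which 3 of the 3 values shown sit).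

Compound 4 `CC(C)=CCC/C(C)=C/C[C@@H]1C[C@]2(CC=C(C)C)C(=O)[C@@](CC=C(C)C)(C(=O)C(C(=O)c3ccc(O)c(OC(=O)CCCC[C@@H]4SCC5NC(=O)NC54)c3)=C2O)[C@@]1(C)CCC=C(C)C` has not yet been measured. It differs from compound 1 by a group of 12 heavy atoms (8 carbon, 2 nitrogen, 1 oxygen, 1 sulfur; one five-membered non-aromatic ring with 1 hetero atom, one five-membered non-aromatic ring with 2 hetero atoms) in place of a hydrogen atom, on a saturated chain carbon bound to a carbonyl carbon. For the measured compounds named here, the one measured step that bears on this change is a step that the two limits leave unreadable from compound 1 to compound 2, which places acetyl in place of hydrogen on an oxygen on an aromatic ring. That step has no readable size, so it offers no measure for the new change. Nothing measured points to a gain in inhibition, given (the limit of > 20000 nM in this assay, at which 3 of the 3 values shown sit). In this assay, no step beyond the scatter is therefore expected, in either direction. The estimated step is a step that the limit leaves unreadable from compound 1 to compound 4. The expected value for compound 4 is 25000 nM, with an estimated range of 12000 nM to 50000 nM.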

Compound 4, half-maximal inhibitory concentration: 12100 nM
Estimate against measurement, compound 4: 2.1-fold (0.32 log units) above, within the range that was stated.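

In this assay, the group of 12 heavy atoms in place of a hydrogen atom, on a saturated chain carbon bound to a carbonyl carbon, gives an at least 1.6-fold lower number from compound 1 to compound 4 (0.21 log units; that floor lies within the scatter). Compound 4 is thus the only compound shown with a number rather than a limit, so this change yields a step with a readable floor, whereas the steps between compounds at the limit cannot be read. That floor does not establish a gain beyond the scatter, and the rest of the series stays at the limit: the limit of > 20000 nM in this assay, at which 3 of the 4 values shown sit.

From the compounds shown here alone, the value of compound 1 is a limit and not a number, so the full size of the step stays open. Also open, going by these compounds, is whether a plain longer chain or an amine at this place would give a number too, or whether the two five-membered rings are needed.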